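This account rests on a few compounds, and the source may have more. Where it says the series, first, only, none or still open, it means among the compounds named here.

Working notes on the series. Compound 1, `COc1ccc(C(=O)Nc2nccn3cc(-c4ccccc4)nc23)cc1`, gives 1% in an assay on cells for displacement of a labelled ligand from adenosine receptor A1 (Homo sapiens), read by scintillation counting, with a stated time of 120 min, tested at 1 uM; on this read-out higher numbers stand for more inhibition at the one concentration tested (going by the name of the read-out) and lower numbers for less inhibition. Compound 2, `COc1ccc(C(=O)Nc2nc(-c3ccccc3)cn3cc(-c4ccccc4)nc23)cc1`, carries phenyl in place of hydrogen on an aromatic carbon and in this assay compound 2 gives 6%. The one measured step, a number 5 percentage points higher from compound 1 to compound 2 (within the scatter), lies within the scatter, so on the two numbers shown compound 2 stands alongside compound 1 rather than apart from it; both are small numbers in this assay.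

Compound 3, `O=C(Nc1nc(-c2ccccc2)cn2cc(-c3ccccc3)nc12)c1ccc(Cl)cc1`, differs from compound 2 in one place: chloro in place of methoxy on an aromatic carbon. Among the measured compounds shown here, no measured step touches the substituent on the six-membered ring of the amide part, so nothing bears directly on this change; the only step available, a number 5 percentage points higher from compound 1 to compound 2 (within the scatter), concerned a different position and was within the scatter. With both measured numbers low and no step beyond the scatter so far, the expected step in this assay, a number 2 percentage points higher from compound 2 to compound 3 (within the scatter), is none beyond the scatter. For compound 3 the estimate in this assay is 8%, expected to fall between 0% and 25%.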

Compound 3, a percentage reported as inhibition, at one concentration (the size of the read-out at that concentration, not a potency): 1%
Estimate against measurement, compound 3: 7 percentage points above; low and high end bracket the measured number.
By their numbers in this assay, from the lowest: compounds 1, 3 and 2 (each within the scatter of the next).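

The change from 4-methoxyphenyl to 4-chlorophenyl, on an aromatic carbon para to a large group, is the only reading at this position among the compounds shown; in this assay it gives a number 5 percentage points lower from compound 2 to compound 3 (within the scatter). Methoxy, with 2 heavy atoms and 1 hydrogen-bond acceptor, therefore gives way to chloro, with 1 heavy atom and 0 hydrogen-bond acceptors, without a step beyond the scatter, so this single exchange shows no sensitivity to the substituent at the one concentration tested. No measurement at hand explains this result or ties it to a property of either group.

Since this exchange starts from a small number and stays within the scatter, it cannot show whether this position could support a larger number in this assay or is simply indifferent to substitution. As far as these compounds go, an amine, a carboxylic acid or a longer alkoxy chain in place of methoxy on this ring remains open, as does whether any such group would give a step beyond the scatter.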